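The compounds below may be only part of what the source reports. "The series", "measured", "known", "first", "only" and "open" are said of these compounds alone.

Measured in a functional assay on DU-145 cells (Homo sapiens) for inhibition, read by trypan blue exclusion, with a stated time of 96 h; on this read-out lower numbers stand for stronger inhibition of growth and higher numbers for weaker inhibition of growth:
- compound 1 `O=C(O)c1ccc(C(=O)/C(=C\c2ccc(O)c([N+](=O)[O-])c2)SCc2ccc(Br)cc2)cc1`: 50000 nM
- compound 2 `CN(C)c1ccc(/C=C(/SCc2ccc(Br)cc2)C(=O)c2ccc(C(=O)O)cc2)cc1`: 50000 nM
- compound 3 `O=C(O)c1ccc(C(=O)/C(=C\c2ccc(Cl)c([N+](=O)[O-])c2)SCc2ccc(Br)cc2)cc1`: 500 nM

Compound 1 stands level with compound 2 at the high end of these numbers, and compound 3 lies well below both. Compound 4 `O=C(/C(=C\c1ccc(O)c([N+](=O)[O-])c1)SCc1ccc(Br)cc1)c1ccc([N+](=O)[O-])cc1` keeps the core of compound 1 but has nitro in place of carboxy on an aromatic carbon, para to a large group: nitro in place of carboxy on an aromatic carbon.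

For the measured compounds named here, no measured step touches this place, so the evidence is indirect. Elsewhere on the molecule, changes gave no change at the digits printed from compound 1 to compound 2 (within the scatter), a 100-fold lower number from compound 1 to compound 3 (2.00 log units; beyond the scatter) and a 100-fold lower number from compound 2 to compound 3 (2.00 log units; beyond the scatter). One change can therefore do nothing or a great deal.

Compound 1 sits at 50000 nM, and compound 3 shows that a far lower number is reachable at 500 nM. A moderate step towards a lower number in this assay is therefore expected, though no change at all remains possible. The expected move is a 10-fold lower number from compound 1 to compound 4 (1.00 log units; beyond the scatter), an estimate only. For compound 4 the estimated value is 5000 nM, with an expected range of 500 nM to 50000 nM.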

Compound 4, concentration for 50% growth inhibition: 10000 nM
For compound 4 the middle estimate is 2.0-fold (0.30 log units) below the measured one; the range from low to high includes it.
By their numbers in this assay, from the lowest: compound 3; then compound 4; then compounds 1 and 2 (each within the scatter of the next).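

For the compounds shown here, this is the first reading at this position on the shared core: in this assay, moving from 4-carboxyphenyl to 4-nitrophenyl gives a 5.0-fold lower number from compound 1 to compound 4 (0.70 log units; beyond the scatter). The carboxy group is therefore not essential for growth inhibition at this level, since a group with no hydrogen-bond donor still gives a modest gain, though a smaller one than the step on the other ring, a 100-fold lower number from compound 1 to compound 3 (2.00 log units; beyond the scatter). Nothing shown here explains why this swap moves the number.

From the compounds shown here alone, it remains open whether an amine or an amide at this position would do better or worse than nitro. The compounds shown also leave open whether nitro in place of carboxy would lower the number further when combined with the chloro group of compound 3.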